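This account rests on a few compounds, and the source may have more. Where it says the series, first, only, none or still open, it means among the compounds named here.

Values in a functional assay on SK-MEL-147 cells (Homo sapiens) for cytotoxicity, read by MTT assay, with a stated time of 24 h; a higher number here means that more compound is needed for the effect, a lower number that less compound is needed:
- Compound 1 `CCOC(=O)c1cc([Se]c2ccccc2)c2cc(Br)ccc2n1`: 12400 nM
- Compound 2 `CCOC(=O)c1cc([Se]c2ccccc2)c2cc(OC)ccc2n1`: 33000 nM
- Compound 3 `CCOC(=O)c1cc([Se]c2ccc(OC)cc2)c2cc(OC)ccc2n1`: >= 54300 nM, which is a limit and not a number

Of the two true numbers, the higher belongs to compound 2 and the lower to compound 1.

The next compound is compound 4 `CCOC(=O)c1cc([Se]c2ccccc2)c2ccccc2n1`, with hydrogen in place of methoxy on an aromatic carbon.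

Going by the values given here, two measured steps bear on this change. The closer one also concerns the methoxy of compound 2: a 2.7-fold higher number from compound 1 to compound 2 (0.43 log units; beyond the scatter). The other adds a second methoxy, in place of hydrogen, and gives an at least 1.6-fold higher number from compound 2 to compound 3 (0.21 log units; that floor lies within the scatter). This second step rests on (the limit of >= 54300 nM in this assay, at which 1 of the 3 values shown sits).

In both steps, gaining a methoxy goes with a higher number, and neither step is large. Removing the methoxy is therefore expected to give a small move toward a lower number in this assay.

The expected change is a 1.8-fold lower number from compound 2 to compound 4 (0.26 log units; within the scatter).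

For compound 4 the estimate is 18000 nM, with an expected range from 8000 nM to 40000 nM.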

Compound 4, half-maximal effective concentration: 86300 nM
Compound 4: the middle estimate sits 4.8-fold (0.68 log units) below what was measured; measured number outside the range, above it.
By their numbers in this assay, from the lowest: compound 1; then compound 2; then compound 4.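

Hydrogen at this position, on the carbon-only aromatic ring of the shared core, is the poorest of the three groups compared in this assay, not the mild improvement that the methoxy step suggested: the change gives a 2.6-fold higher number from compound 2 to compound 4 (0.42 log units; beyond the scatter), and hydrogen in place of bromo gives a 7.0-fold higher number from compound 1 to compound 4 (0.84 log units; beyond the scatter). Both methoxy and bromo therefore go with a lower number than hydrogen here, so the earlier comparison of methoxy with bromo ranked two substituents and gave no direction relative to the unsubstituted compound. Nothing shown here accounts for this order.

Going by these compounds, whether other groups at this position, such as an amine, a chloro or a hydroxyl, also give a lower number than hydrogen remains open. On these data alone, it is equally open whether bromo stays ahead of them.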